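This account rests on a few compounds, and the source may have more. Where it says the series, first, only, none or still open, it means among the compounds named here.

Measured in a functional assay on MCF7 cells (Homo sapiens) for inhibition, read by sulforhodamine B assay; a lower number here means a stronger inhibitor of growth, a higher number a weaker inhibitor of growth:
- Compound 1 `Cc1ccc2[nH]c(-c3ccc(-c4ccc(-c5ccc(N(C)C)cc5)cc4)cc3)nc2c1`: 3130 nM
- Compound 2 `COc1cc(-c2ccc(-c3ccc(-c4nc5cc(C)ccc5[nH]4)cc3)cc2)cc(OC)c1OC`: 170 nM
- Compound 3 `Fc1ccc(-c2ccc(-c3ccc(-c4nc5ccccc5[nH]4)cc3)cc2)cc1`: 36200 nM

Among these, compound 3, at 36200 nM, has the highest number, beyond the scatter from both others and so the weakest inhibitor of growth of the set. Compound 4 `Oc1ccc(-c2ccc(-c3ccc(-c4nc5ccccc5[nH]4)cc3)cc2)cc1` carries hydroxy in place of fluoro on an aromatic carbon, para to a large group: hydroxy in place of fluoro on an aromatic carbon. Among the measured compounds shown here, no measured pair isolates this change, and compound 1 and compound 2 differ from compound 3 in more than one place. Since compound 3 already stands so high, a moderate move toward a lower number is expected, though with wide uncertainty. The expected change is a 6.0-fold lower number from compound 3 to compound 4 (0.78 log units; beyond the scatter). The estimated value for compound 4 is 6000 nM, with an expected range from 1000 nM to 36000 nM.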

Compound 4, concentration for 50% growth inhibition: 30500 nM
Beside the measured number, compound 4's estimate is 5.1-fold (0.71 log units) below it; low and high end bracket the measured number.
By their numbers in this assay, from the lowest: compound 2; then compound 1; then compounds 4 and 3 (each within the scatter of the next).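

In this assay, among the compounds shown here, going from 4-fluorophenyl to 4-hydroxyphenyl gives a 1.2-fold lower number from compound 3 to compound 4 (0.07 log units; within the scatter) and this is the first pair that differs in one place only. On this aromatic carbon, para to a large group, the assay does not separate hydroxy from fluoro, even though hydroxy brings a hydrogen-bond donor that fluoro lacks. Nothing measured here offers an explanation for this result.

On these data alone, whether a carboxylic acid or a longer chain in this place would also read the same remains open. So does whether the same exchange would give a similar step on the core of compound 2.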